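Three Amides at the Cytotoxicity Limit, a Fourth to Come

The source may report more compounds than this note shows. Statements on the series, on what has been measured and on what is new or still open speak of the compounds shown alone.

compound 1 `Cc1ccccc1NC(=O)c1ccc2cccc(O)c2n1` — > 30000 nM
compound 2 `O=C(Nc1ccccc1F)c1ccc2cccc(O)c2n1` — > 30000 nM
compound 3 `O=C(Nc1ccc(F)cc1)c1ccc2cccc(O)c2n1` — > 30000 nM

In an ADME assay on THP-1 cells (Homo sapiens) for cytotoxicity, read by WST assay, with a stated time of 24 h (on this read-out lower numbers stand for stronger inhibition and higher numbers for weaker inhibition), compound 1 gives > 30000 nM, which is a limit of the assay and not a number. Compound 2 gives > 30000 nM in this assay, again a limit. Compound 3 gives > 30000 nM, also a limit. For the measured compounds named here, every value measured so far therefore sits at the limit of > 30000 nM in this assay, at which 3 of the 3 values shown sit. The steps between them carry no readable size: a step that the two limits leave unreadable from compound 1 to compound 2, a step that the two limits leave unreadable from compound 1 to compound 3 and a step that the two limits leave unreadable from compound 2 to compound 3 all stay hidden behind the two limits.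

The compound still to be measured is compound 4 `O=C(Nc1ccccc1Cl)c1ccc2cccc(O)c2n1`. It differs from compound 1 by chloro in place of methyl on an aromatic carbon. Going by the values given here, the steps that bear on it, fluoro in place of methyl and the two exchanges of the aryl group on the amide nitrogen, were all unreadable, so nothing points to a step beyond the scatter in either direction. Compound 4 is therefore expected to show a number no higher from compound 1 to compound 4 (the limit leaves the size open), most likely ending at the limit once more. The estimate for compound 4 is 30000 nM, with a range from 12000 nM to 80000 nM.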

Compound 4, half-maximal inhibitory concentration: > 30000 nM
Compound 4 ended at the assay's limit; the forecaster's own chance of this, stated with the estimate: 80%; the middle value sits exactly at the limit.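

Compound 4 sits with compound 1, compound 2 and compound 3 at a limit and not at a number, so none of the new steps to compound 4 can be read in this assay: the limit of > 30000 nM in this assay, at which 4 of the 4 values shown sit.

The compounds shown leave open whether any other group on the amide nitrogen would give a readable number in this assay.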